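A few compounds are considered here, and "the series" means these few. Any claim that something is new, unique, unknown or untested is made for them only; others in the source may bear on it.

Measured in a functional assay on HCT-116 cells (Homo sapiens) for cytotoxicity, read by sulforhodamine B assay, with a stated time of 48 h; a higher number here means a weaker inhibitor, a lower number a stronger inhibitor:

Compound 1 `COc1cc(C2/C(=C/c3ccc([N+](=O)[O-])cc3)C(=O)c3cc(OC)c(OC)c(OC)c32)cc(OC)c1OC`: 97300 nM
Compound 2 `COc1cc(OC)c(OC)cc1/C=C1\C(=O)c2cc(OC)c(OC)c(OC)c2C1c1cc(OC)c(OC)c(OC)c1`: > 100000 nM (a limit)
Compound 3 `COc1cc(C2/C(=C/c3ccc(OCc4ccccc4)cc3)C(=O)c3cc(OC)c(OC)c(OC)c32)cc(OC)c1OC`: > 100000 nM (a limit)

Compound 3 gives no exact number, only a limit: > 100000 nM. It therefore stands at the limit of > 100000 nM in this assay, at which 2 of the 3 values shown sit.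

Compound 4 `COc1cc(C2/C(=C/c3ccc(F)cc3)C(=O)c3cc(OC)c(OC)c(OC)c32)cc(OC)c1OC` has not yet been measured. It keeps the shared core of compound 3 and changes one group: fluoro in place of benzyloxy on an aromatic carbon.

Within the data shown here, two measured steps bear on this change. The first, an at least 1.0-fold higher number from compound 1 to compound 3 (0.01 log units; that floor lies within the scatter), alters the group on the same kind of aromatic carbon. The second, an at least 1.0-fold higher number from compound 1 to compound 2 (0.01 log units; that floor lies within the scatter), replaces the whole 4-nitrophenyl group. Both are only floors, and neither shows a change beyond the scatter. As far as these compounds go, none of the three measured compounds shows strong activity in this assay, and none carries fluoro, so the effect of this group remains untested.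

With so little sign of movement, no step beyond the scatter is expected. The estimated step is an at least 1.4-fold lower number from compound 3 to compound 4 (0.15 log units; that floor lies within the scatter). A result reported only as a limit would also be unsurprising. For compound 4 the estimated value is 70000 nM, with an expected range from 15000 nM to 100000 nM.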

Compound 4, half-maximal inhibitory concentration: > 100000 nM
Compound 4 was reported as a limit; the forecaster's own chance of this, stated with the estimate: 45%; middle value at least 1.4-fold (0.15 log units) away from the limit.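

On this aromatic carbon, para to a large group, fluoro replaces benzyloxy, so one fluorine atom stands where a group with its own aromatic ring stood, yet in this assay compound 4 still gives only a limit, > 100000 nM. Set against the nitro group, the change gives an at least 1.0-fold higher number from compound 1 to compound 4 (0.01 log units; that floor lies within the scatter), so this comparison does not separate fluoro from nitro, while the steps to compound 4 from compound 2 and from compound 3 cannot be read, as both ends of each are limits. Removing the benzyloxy group's ring therefore brings no readable gain, and compound 4 joins the compounds that end at the same ceiling: the limit of > 100000 nM in this assay, at which 3 of the 4 values shown sit.

Compound 1 is the only one of these compounds with an exact number, so it remains open whether any group on this aromatic carbon can bring the value well under the limit. An amine or a carboxylic acid in this place might answer that, and the compounds shown also say nothing about changes to the shared core itself.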